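Shortening a Chain While Every Value Sits at a Limit

This account rests on a few compounds, and the source may have more. Where it says the series, first, only, none or still open, it means among the compounds named here.

Compound 1 `CCCCCCNc1cnc(C(=O)NCc2ccccc2)cn1` is the starting point. In an ADME assay on HEL cells (Homo sapiens) for cytotoxicity, read by microscopy, with a stated time of 6 days (a lower number here means that less compound is tolerated, a higher number that more compound is tolerated), compound 1 gives > 100000 nM, which is a limit of the assay and not a number. Compound 2 `CCCCCNc1nccnc1C(=O)NCc1ccccc1` gives >= 100000 nM in this assay, again a limit rather than a measured number. Compound 3 `CCCCCCCCNc1cncc(C(=O)NCc2ccccc2)n1` gives > 100000 nM in this assay, also a limit. So every value measured so far rests at the edge of what the assay can report, as shown by the limit of > 100000 nM in this assay, at which 2 of the 3 values shown sit, and (the limit of >= 100000 nM in this assay, at which 1 of the 3 values shown sits), and no ordering among compound 1, compound 2 and compound 3 can be read from them.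

Compound 4 `CCCCCNc1cnc(C(=O)NCc2ccccc2)cn1` has not yet been measured. It differs from compound 1 by hydrogen in place of methyl on a saturated chain carbon, five bonds along the chain from a nitrogen on an aromatic ring. Among the compounds with values here, no step between measured compounds is available to set a size for such a change, and since all three values sit at the limit, the step of a number no higher from compound 1 to compound 4 (the limit leaves the size open) is expected to be none beyond the usual scatter. Compound 4 is expected to give about 100000 nM, within 50000 nM to 200000 nM, most likely reported as a limit once more.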

Compound 4, minimum cytotoxic concentration: > 100000 nM
Compound 4: only a limit was reported; the forecaster's own chance of this, stated with the estimate: 85%; the middle value sits exactly at the limit.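

In this assay compound 4 gives > 100000 nM, which is a limit of the assay and not a number. Within the data shown here, compound 1 also sits at a limit, so no step from one to the other can be read. The compounds shown leave open at what concentration any of them would harm these cells, and whether chain length alters that concentration.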